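The source may hold more compounds than are shown below. What is called first, only, known or untested is meant among the compounds shown, and "the series" means these compounds.

Series notes. Compound 1 `CCN(CC)S(=O)(=O)c1ccc(S(=O)(=O)N2CCC[C@@H](C(=O)NC3CN(C(=O)C4CC4)C3)C2)cc1` gives 3100 nM in a functional assay on MIA PaCa-2 cells (Homo sapiens) for inhibition, read by MTT assay, with a stated time of 3 days (on this read-out higher numbers stand for weaker inhibition and lower numbers for stronger inhibition), the highest of the two numbers in hand; compound 2 `CC(C)c1noc(C2CCN(C(=O)[C@@H]3CCCN(S(=O)(=O)c4ccc(S(=O)(=O)C(C)C)cc4)C3)CC2)n1` gives 20 nM, a far lower number, well beyond the scatter. Compound 3 `CCN(CC)S(=O)(=O)c1ccc(S(=O)(=O)N2CCC[C@@H](C(=O)N3CCN(c4nc(C)no4)CC3)C2)cc1` is the next member, differing from compound 1 by 4-(3-methyl-1,2,4-oxadiazol-5-yl)piperazin-1-yl in place of (1-(cyclopropylcarbonyl)azetidin-3-yl)amino on a carbonyl carbon. No such change has been measured directly. Since compound 2, which also carries an oxadiazole on a saturated nitrogen ring at the amide, gives 20 nM, a step towards stronger inhibition is expected from compound 1 to compound 3, estimated at a 21-fold lower number from compound 1 to compound 3 (1.32 log units; beyond the scatter). For compound 3 the expected value is 150 nM, within 30 nM to 800 nM.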

Compound 3, half-maximal inhibitory concentration: 200 nM
Compound 3: the middle estimate sits 1.3-fold (0.12 log units) below what was measured; the range from low to high includes it.
By their numbers in this assay, from the lowest: compound 2; then compound 3; then compound 1.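

With the rest of compound 1 held fixed, the group on the carbonyl carbon alone carries a large change in this assay: 4-(3-methyl-1,2,4-oxadiazol-5-yl)piperazin-1-yl in place of (1-(cyclopropylcarbonyl)azetidin-3-yl)amino gives a 16-fold lower number from compound 1 to compound 3 (1.19 log units; beyond the scatter) as the step. The entering group has 0 hydrogen-bond donors where the leaving group has 1, and it also brings different rings, so this single step does not separate those differences. No measurement in hand accounts for the step. From the compounds shown here alone, it remains open whether the step follows the oxadiazole ring or the piperazine ring. An acetyl group in place of the 3-methyl-1,2,4-oxadiazol-5-yl group on the piperazine would test this.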